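The source may report more compounds than this note shows. Statements on the series, on what has been measured and on what is new or still open speak of the compounds shown alone.

Compounds measured in a functional assay on FaDu cells (Homo sapiens) for cytotoxicity, read by MTT assay, with a stated time of 72 h; a higher number here means that more compound is tolerated, a lower number that less compound is tolerated:
compound 1 `COc1ccc(NC(=O)C(=O)c2cn(C(C)C)c3cccnc23)cn1` — > 10000 nM
compound 2 `COc1ccc(NC(=O)C(=O)c2cn(C(C)C)c3cccc(Cl)c23)cn1` — 2130 nM
compound 3 `COCC(C)n1cc(C(=O)C(=O)Nc2ccc(OC)nc2)c2ccccc21` — 12 nM

The value for compound 1, > 10000 nM, is a limit of the assay and not a number. Among the two compounds with a number, compound 3 gives the lowest value in this assay, and the nearest, compound 2, sits far higher, beyond the scatter of repeated measurements. No step between two measured compounds differing in a single place is shown, so the account now turns to one unmeasured compound.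

Compound 4 `COc1ccc(NC(=O)C(=O)c2cn(CCC(=O)O)c3ccccc23)cn1` differs from compound 3 as follows: 2-carboxyethyl in place of 1-(methoxymethyl)ethyl on an aromatic nitrogen. For this change no measured comparison exists among the compounds shown. The expectation is a step from compound 3 to compound 4 of considerable size towards a higher number, beyond the scatter, estimated as a 210-fold higher number from compound 3 to compound 4 (2.32 log units; beyond the scatter). For compound 4 in this assay the estimated value is 2500 nM, with a range from 200 nM to 10000 nM, and a real chance that only a limit is reported.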

Compound 4, concentration lethal to 50% of the cells: > 10000 nM
Compound 4 ended at the assay's limit (the forecaster's own chance of this, stated with the estimate: 30%); at least 4.0-fold (0.60 log units) between middle value and limit.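

Going by these compounds alone, on the aromatic nitrogen of the five-membered ring, this pair gives the first comparison of a single change, and that change alone moves the result by a large margin: an at least 830-fold higher number from compound 3 to compound 4 (2.92 log units; beyond the scatter). The two groups have the same count of heavy atoms, so that count does not separate them, whereas 2-carboxyethyl has a hydrogen-bond donor that 1-(methoxymethyl)ethyl lacks. In this assay compound 4 gives > 10000 nM, which is a limit of the assay and not a number, so the step gives only a lower bound: the limit of > 10000 nM in this assay, at which 2 of the 4 values shown sit.

The compounds shown leave open whether the step follows the carboxylic acid itself or the chain that carries it, a question that the methyl ester of the same chain or an amine at its end would address. They also leave open how a 2-methoxyethyl chain or a longer carboxylic acid chain would behave at this position.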